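The source may hold more compounds than are shown below. What is called first, only, known or untested is meant among the compounds shown, and "the series" means these compounds.

In a functional assay on CHO cells for agonist activity at Free fatty acid receptor 2 (Homo sapiens), read by cAMP accumulation (a lower number here means a stronger inhibitor, a higher number a weaker inhibitor), the three measured compounds span a wide range. Compound 1, `CC(C)[C@H](C(=O)NCc1ccccc1)c1ccc(Cl)cc1`, gives > 100000 nM, which is a limit of the assay and not a number. For the measured compounds named here, compound 2, `Cc1csc(NC(=O)[C@H](c2ccc(Cl)cc2)C(C)C)n1`, gives 1400 nM in this assay, and the step of an at least 71-fold lower number from compound 1 to compound 2 (1.85 log units; beyond the scatter) is the one clear change in the set; compound 1 sits at the limit of > 100000 nM in this assay, at which 1 of the 3 values shown sits. Compound 3, `CC(C)(C)[C@H](C(=O)Nc1ncc(F)s1)c1ccc(Cl)cc1`, gives 700 nM in this assay, the lowest of the two numbers shown, though its gap to compound 2 lies within the scatter, so the two cannot be ordered.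

Compound 4, `CC(C)(C)[C@H](C(=O)Nc1ncc(C(F)(F)F)s1)c1ccc(Cl)cc1`, has not yet been measured in this assay. It differs from compound 3 by trifluoromethyl in place of fluoro on an aromatic carbon. No measured step in the set touches this position: the only step shown, from compound 1 to compound 2, concerns the group on the amide nitrogen, not a substituent on the five-membered ring. The expectation for this assay therefore rests on compound 3 alone, and a step of no more than the scatter is expected, with no change at the digits printed from compound 3 to compound 4 (within the scatter) as the estimated change. Compound 4 is estimated to give 700 nM in this assay, within a range from 250 nM to 2000 nM.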

Compound 4, half-maximal inhibitory concentration: 1500 nM
Compound 4: middle estimate off by 2.1-fold (0.33 log units), on the low side, and the stated range covers the measured number.
By their numbers in this assay, from the lowest: compounds 3, 2 and 4 (each within the scatter of the next, the first and the last beyond it). At a limit, above all of these: compound 1.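

For the compounds shown here, this is the first measured change on the five-membered aromatic ring itself. At the aromatic carbon next to the ring sulfur, trifluoromethyl in place of fluoro gives the step of a 2.1-fold higher number from compound 3 to compound 4 (0.33 log units; beyond the scatter) in this assay, which shows that the number responds to the group held at this position, though only modestly. Nothing in the data at hand accounts for the direction or size of this step.

Fluoro and trifluoromethyl are the only two groups compared at this carbon, so they set no trend, and what an amine, a carboxylic acid or a longer chain would do there remains open. Going by these compounds, it also remains open whether the same exchange would give a step of similar size and direction on a compound that differs elsewhere in the shared core, or in any assay other than this assay.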